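The source may hold more compounds than are shown below. What is called first, only, known or untested is meant among the compounds shown, and "the series" means these compounds.

Series notes, a functional assay, with a stated time of 20 min, tested at 50 uM; a lower number here means a weaker effect, a higher number a stronger effect of the compound at the concentration tested:

- compound 1 `COc1cc(/C=C/C(=O)C2=C(/C=C/c3ccc(O)c(OC)c3)NC(=O)NC2c2ccccc2)ccc1O`: 50.2%
- compound 2 `COc1cc(/C=C/C(=O)C2=C(/C=C/c3ccc(O)c(OC)c3)NC(=O)NC2c2ccc(C)cc2)ccc1O`: 52.2%
- compound 3 `COc1cc(/C=C/C(=O)C2=C(/C=C/c3ccc(O)c(OC)c3)NC(=S)NC2c2ccccc2)ccc1O`: 50.4%

Compound 1 and compound 2 share a core and differ by methyl in place of hydrogen on an aromatic carbon. The step of a number 2 percentage points higher from compound 1 to compound 2 (within the scatter) lies within the usual scatter, so the two values show no difference that can be trusted. Compound 3 carries a different core from compound 1; the difference between the two cores is not broken down here. The values of compound 3 and compound 1 sit within the scatter of each other, so nothing is said about their order.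

Compound 4 `COc1cc(/C=C/C(=O)C2=C(/C=C/c3ccc(O)c(OC)c3)NC(=S)NC2c2ccc(C)cc2)ccc1O` has not yet been measured in this assay. It differs from compound 3 by methyl in place of hydrogen on an aromatic carbon, the same change as from compound 1 to compound 2, at the same place in both pairs. Since the change is the same, the step is expected to be of similar size: the estimated step reads a number 1.6 percentage points higher from compound 3 to compound 4 (within the scatter), set beside the measured one, because that earlier step is a number 2 percentage points higher from compound 1 to compound 2 (within the scatter) and gives no sign of a larger shift. Compound 4 is therefore expected to read about 52%, with a range from 42% to 62%.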

Compound 4, a percentage reported as activity, at one concentration (the size of the read-out at that concentration, not a potency): 41%
Estimate against measurement, compound 4: 11 percentage points above, outside the stated range (below it).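

In this assay, the change from phenyl to 4-methylphenyl on the sulfur-bearing core reads a number 9.4 percentage points lower from compound 3 to compound 4 (within the scatter), so this step on its own shows no difference that can be trusted. Set beside the same change on the oxygen-bearing core, it gives no reliable sign that the two cores respond differently: the same change on two cores in this assay, a number 2 percentage points higher (within the scatter) from compound 1 to compound 2 and a number 9.4 percentage points lower (within the scatter) from compound 3 to compound 4, 11.4 percentage points apart, within the scatter of two such steps

Carrying the change from one core to the other is therefore not contradicted, but a single pair on each core does not establish that the step transfers, and it does not fix its size or direction on either core.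

The compounds shown carry only hydrogen or methyl at this place, so the effect of a chlorine atom, a methoxy group, an amine, a carboxylic acid or a longer alkyl chain there remains open on both cores. Each read-out also comes from a single concentration, so it gives only the size of the effect of each of the four compounds at that concentration.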